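This account rests on a few compounds, and the source may have more. Where it says the series, first, only, none or still open, it means among the compounds named here.

Of the compounds shown here, three built on one shared core have been tested in a functional assay on C6 cells (Rattus norvegicus) for cytotoxicity, read by MTT assay, with a stated time of 48 h; on this read-out higher numbers stand for weaker inhibition and lower numbers for stronger inhibition. Compound 1 `CCCCCCCCCCCCCCCCCOC(=O)C1=C(C)NC(=O)NC1c1cccc(O)c1` gives 16700 nM; compound 2 `CCCCCCCC/C=C\CCCCCCCC1=C(C(=O)OC)C(c2cccc(O)c2)NC(=O)N1` gives 166000 nM; compound 3 `CCCCCCCCCCCCCCCC1=C(C(=O)OC)C(c2cccc(O)c2)NC(=S)N1` gives 5110 nM, the lowest of the three numbers, with compound 1 nearest to it and compound 2 furthest away. Compound 4 `CCCCCCCC/C=C\CCCCCCCC1=C(C(=O)OC)C(c2cccc(O)c2)NC(=S)N1` has not yet been measured. It differs from compound 3 in one place: dec-1-en-1-yl in place of octyl on a saturated chain carbon, seven bonds along the chain from a double-bonded ring carbon. Among the measured compounds shown here, no measured pair isolates this change on its own. Compound 2 with 166000 nM and compound 3 with 5110 nM differ both in this chain and elsewhere, so that gap cannot be split between the two changes. The step toward a higher number is expected to be about a 5.9-fold higher number from compound 3 to compound 4 (0.77 log units; beyond the scatter). Compound 4 is therefore estimated at 30000 nM, within a range from 6000 nM to 150000 nM.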

Compound 4, half-maximal inhibitory concentration: 38400 nM
For compound 4 the middle estimate is 1.3-fold (0.11 log units) below the measured one, within the range that was stated.
By their numbers in this assay, from the lowest: compound 3; then compound 1; then compound 4; then compound 2.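

In this assay, the exchange of octyl for dec-1-en-1-yl on a saturated chain carbon, seven bonds along the chain from a double-bonded ring carbon, can now be read on its own as a 7.5-fold higher number from compound 3 to compound 4 (0.88 log units; beyond the scatter) and points to weaker inhibition. Thus, this part of the chain is not indifferent to the change. Nothing here bears on the reason for this step. The pair leaves open whether the added carbons or the double bond carries the step. A saturated decyl chain, or a chain ending in a carboxylic acid, remains unplaced.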